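Thienyl pyrimidinone series: ester and ketone side chains

This account rests on a few compounds, and the source may have more. Where it says the series, first, only, none or still open, it means among the compounds named here.

Measured compounds:
compound 1 `CCCOC(=O)C1=C(C)N(C)C(=O)NC1c1cccs1` gives 4%
compound 2 `CC1=C(C(=O)OCC(C)C)C(c2cccs2)NC(=O)N1C` gives 5%
compound 3 `CCCC(=O)C1=C(C)NC(=O)NC1c1cccs1` gives 2%

All three values come from an assay on membranes from HeLa cells for displacement of a labelled ligand from adenosine receptor A3 (Homo sapiens), read by scintillation counting, with a stated time of 180 min, tested at 1 uM; a lower number here means less inhibition, a higher number more inhibition at the concentration tested (going by the name of the read-out). Compound 1 and compound 2 share one core and differ by methyl in place of hydrogen on a saturated chain carbon bound to two saturated chain carbons. That change made a step of a number 1 percentage points higher from compound 1 to compound 2 (within the scatter), so compound 1 and compound 2 read as the same within the scatter. Compound 3 carries a different core; the difference between the two cores is not broken down here. Its value in this assay lies with those of compound 1 and compound 2, all three within the scatter of one another, so no order among them can be stated.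

Compound 4 `CC1=C(C(=O)CC(C)C)C(c2cccs2)NC(=O)N1` is not yet measured. It differs from compound 3 by methyl in place of hydrogen on a saturated chain carbon bound to two saturated chain carbons, which is the same change as that from compound 1 to compound 2, placed on the same kind of carbon. Because a number 1 percentage points higher from compound 1 to compound 2 (within the scatter) stayed within the scatter, the same change on the core of compound 3 is expected to stay within the scatter as well. The expected step is a number 1 percentage points higher from compound 3 to compound 4 (within the scatter), to be set beside the measured a number 1 percentage points higher from compound 1 to compound 2 (within the scatter). Compound 4 is therefore estimated to give 3% in this assay. The range expected for compound 4 runs from -6% to 12%, which covers the low inhibition seen for compound 1, compound 2 and compound 3.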

Compound 4, a percentage reported as inhibition, at one concentration (the size of the read-out at that concentration, not a potency): 18%
Estimate against measurement, compound 4: 15 percentage points below; the whole stated range lies below it.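

In this assay, going from propylcarbonyl to isobutylcarbonyl gives a number 16 percentage points higher from compound 3 to compound 4 (beyond the scatter), whereas the same methyl in place of hydrogen left the ester pair unresolved, so the size of this step did not carry from one core to the other: the same change on two cores in this assay, a number 1 percentage points higher (within the scatter) from compound 1 to compound 2 and a number 16 percentage points higher (beyond the scatter) from compound 3 to compound 4, 15 percentage points apart, beyond the scatter of two such steps. A step read on the core of compound 1 therefore cannot serve on its own as a guide to the same change on the core of compound 3, and the step for this change has to be read separately on each core. The result does not show why the two cores part, as the difference between them is not broken down, and it rests on one pair per core at a single concentration, so it gives a size of inhibition at that concentration and no potency.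

Open, going by these compounds, is whether the inhibition on the core of compound 3 keeps moving with a longer chain, or with a cyclohexyl group in place of isobutyl. Also open, on these data alone, is which of the features separating the two cores goes with the gap, and whether an amine or a carboxylic acid on the side chain would leave the number in this assay higher, lower or level on either core.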